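Swapping Chloromethyl for Vinyl on a Carbonyl Carbon

The source may hold more compounds than are shown below. What is called first, only, known or untested is meant among the compounds shown, and "the series" means these compounds.

For the measured compounds named here, in a functional assay on Maver1 cells (Homo sapiens) for inhibition, read by luminescence and CellTiter-Glo, with a stated time of 72 h (a lower number here means a stronger inhibitor, a higher number a weaker inhibitor), compound 1 (`O=C(CCl)N1CCCC(n2nc(-c3ccc(Oc4ccccc4)cc3)cc2CO)C1`) gives 1100 nM, the higher of the two numbers measured so far. Compound 2 (`CCOC(=O)c1cc(-c2ccc(Oc3ccccc3)cc2)nn1Cc1ccc(NC(=O)CCl)cc1`) gives 400 nM, and the gap between these two values lies beyond the usual scatter. Compound 1 is therefore the weaker inhibitor of the pair, though the two compounds differ in more than one place and cannot show what any single change does.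

The next compound to be tested is compound 3 (`C=CC(=O)N1CCCC(n2nc(-c3ccc(Oc4ccccc4)cc3)cc2CO)C1`). It keeps the core of compound 1 and makes one exchange: vinyl in place of chloromethyl on a carbonyl carbon. Read one bond further out, (chloromethyl)carbonyl becomes vinylcarbonyl, still attached to an amide-type nitrogen in a ring.

Going by the values given here, no measured pair shows this exchange, so the expectation is only loosely grounded and the direction is uncertain. The estimate is a 1.4-fold lower number from compound 1 to compound 3 (0.14 log units; within the scatter), a change expected to stay within the scatter of this assay. For compound 3, the estimated value is 800 nM, with an expected range from 200 nM to 3000 nM.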

Compound 3, half-maximal inhibitory concentration: 30500 nM
The estimate for compound 3 lay 38-fold (1.58 log units) below the measured number; the measured number lies above the stated range.
By their numbers in this assay, from the lowest: compound 2; then compound 1; then compound 3.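

In this assay the exchange of chloromethyl for vinyl on a carbonyl carbon gives a 28-fold higher number from compound 1 to compound 3 (1.44 log units; beyond the scatter) and so makes compound 3 a much weaker inhibitor than compound 1, which shows that this position is highly sensitive to which of these two groups it carries. The computed comparison gives both groups the same number of heavy atoms and neither group any hydrogen-bond donors or acceptors, so these simple counts do not separate two groups that differ so sharply in the assay. No measurement at hand accounts for the size of this step.

On these data alone, with only chloromethyl and vinyl to compare at this position, it remains open where other groups on the same carbonyl carbon, such as bromomethyl, ethyl or a longer chain, would fall relative to compound 1 and compound 3. As far as these compounds go, it also remains open whether the same exchange in compound 2, which likewise carries chloromethyl on a carbonyl carbon, would produce a step of similar size.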